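The source may hold more compounds than are shown below. What is called first, only, known or untested is meant among the compounds shown, and "the series" means these compounds.

Working notes on the series.

The shared core of compound 2 `CCN1CCC(n2cc(S(=O)(=O)c3cccc(F)c3)c3cccnc32)C1` carries a fluoro group on the pendant aromatic ring and a 1-ethylpyrrolidin-3-yl group on the aromatic nitrogen. Among the measured compounds shown here, in an assay on HeLa cells for displacement of a labelled ligand from 5-hydroxytryptamine receptor 6 (Homo sapiens) (a lower number here means a stronger inhibitor, a higher number a weaker inhibitor), compound 2 gives 8.3 nM, the highest number among the three compounds measured so far. Compound 3 `CCN1CCC(n2cc(S(=O)(=O)c3cccc(Cl)c3)c3cccnc32)C1` gives 3.3 nM in this assay, and compound 1 `O=S(=O)(c1cccc(C(F)(F)F)c1)c1cn(C2CCNC2)c2ncccc12` gives 1.3 nM. For the measured compounds named here, the only single-point step recorded is a 2.5-fold lower number from compound 2 to compound 3 (0.40 log units; beyond the scatter); compound 1 differs from compound 2 in two places at once, so its value shows only that the unsubstituted pyrrolidine with trifluoromethyl sits well below compound 2 in this assay.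

Compound 4 `CC(C)N1CCCC(n2cc(S(=O)(=O)c3cccc(F)c3)c3cccnc32)C1` is not yet measured. It differs from compound 2 as follows: 1-isopropylpiperidin-3-yl in place of 1-ethylpyrrolidin-3-yl on an aromatic nitrogen. Going by the values given here, no measured step touches the amine-bearing ring or its alkyl group, so the fluoro-to-chloro step gives no direct guidance, and the gap from compound 2 to compound 1 mixes two changes. Without a comparable step the expectation is for no change beyond the scatter, though widening the range toward a weaker number. For compound 4 the estimate in this assay is 12 nM, with a range of 3 nM to 45 nM, which means an expected step of a 1.4-fold higher number from compound 2 to compound 4 (0.16 log units; within the scatter).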

Compound 4, inhibition constant: 3.4 nM
Compound 4: the middle estimate sits 3.5-fold (0.55 log units) above what was measured; the range from low to high includes it.
By their numbers in this assay, from the lowest: compound 1; then compounds 3 and 4 (each within the scatter of the next); then compound 2.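

Among the compounds shown here, the first single-place step on the amine-bearing group shows that this position, on an aromatic nitrogen, responds to change in this assay: with the fluoro group held constant, 1-isopropylpiperidin-3-yl in place of 1-ethylpyrrolidin-3-yl gives a 2.4-fold lower number from compound 2 to compound 4 (0.39 log units; beyond the scatter) as a modest but real gain, so the larger six-membered ring with its branched alkyl group is accepted here without any loss. For the compounds shown here, until now the only single-place reading lay on the pendant aromatic ring, and the unsubstituted pyrrolidine of compound 1 could not be read on its own, so this is the first direct information about the group on the aromatic nitrogen. Ring size and alkyl group change together in this step, so it cannot be divided between them, and no measurement to hand offers an explanation for it.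

A 1-ethylpiperidin-3-yl group and a 1-isopropylpyrrolidin-3-yl group would separate those two changes, and an unsubstituted piperidine or a longer chain such as n-butyl on the ring nitrogen would test how far the position extends. As far as these compounds go, whether chloro or trifluoromethyl on the pendant ring combines with the 1-isopropylpiperidin-3-yl group also remains open.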